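A Larger Acyl Group on Compound 2

The source may hold more compounds than are shown below. What is called first, only, known or untested is meant among the compounds shown, and "the series" means these compounds.

Measured in a functional assay on NCI-H1975 cells (Homo sapiens) for antiproliferative activity (on this read-out lower numbers stand for stronger inhibition and higher numbers for weaker inhibition), are two compounds:
compound 1 `Cc1c2c(n3c1CCCN(C)[C@@H](C)[C@H](C)Nc1cc-3ccc1C(N)=O)CC(C)(C)CC2=O` gives 69 nM
compound 2 `CC(=O)N1CCc2c(C)c3c(n2-c2ccc(C(N)=O)c(c2)N[C@@H](C)[C@H](C)C1)CC(C)(C)CC3=O` gives 15 nM

Of these two, compound 2 has the lower number, (15 nM) against compound 1 at (69 nM), a gap beyond the usual scatter. It therefore stands as the stronger inhibitor of the pair in this assay and is the starting point here.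

The next compound, compound 3 `Cc1c2c(n3c1CCN(C(=O)C1(N)CC1)C[C@@H](C)[C@H](C)Nc1cc-3ccc1C(N)=O)CC(C)(C)CC2=O`, has not yet been measured. It differs from compound 2 in one place: 1-aminocyclopropyl in place of methyl on a carbonyl carbon with 1-aminocyclopropyl in place of methyl on a carbonyl carbon that also carries an amide-type nitrogen in a ring.

Among the measured compounds shown here, no measured step shows what this change does, so the expectation rests on compound 2 at (15 nM) alone. The estimated step (a 1.2-fold lower number from compound 2 to compound 3 (0.06 log units; within the scatter)) is expected to stay within the scatter, with no firm direction. For compound 3 the expected value is 13 nM with an estimated range from 4 nM to 40 nM in this assay as the read-out.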

Compound 3, half-maximal inhibitory concentration: 72 nM
Compound 3: the middle estimate sits 5.5-fold (0.74 log units) below what was measured; the measured number lies above the stated range.
By their numbers in this assay, from the lowest: compound 2; then compounds 1 and 3 (each within the scatter of the next).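

Replacing methyl with 1-aminocyclopropyl on a carbonyl carbon that also carries an amide-type nitrogen in a ring gives a 4.8-fold higher number from compound 2 to compound 3 (0.68 log units; beyond the scatter) in this assay and so moves the read-out towards weaker inhibition. Among the compounds shown here, this is the first reading of how this position responds to a change, which compound 2 alone could not give, and it shows that acetyl cannot be exchanged here for (1-aminocyclopropyl)carbonyl without a loss beyond the scatter. Nothing at hand accounts for this loss.

The change brings in several things at once, namely more heavy atoms, a three-membered ring of carbon only and an amine, so the compounds shown leave open which of these goes with the step. Cyclopropyl without the amine, or aminomethyl without the ring, on the same carbonyl carbon would separate the two, and whether any group on this carbonyl carbon gives a lower number than methyl remains an open question.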